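This account rests on a few compounds, and the source may have more. Where it says the series, first, only, none or still open, it means among the compounds named here.

Compounds measured so far in an assay on isolated protein for inhibition of Rho-associated protein kinase 1 (Homo sapiens), read by scintillation counting, radiometric assay and 33P incorporation, with a stated time of 40 min, in the presence of a further agent that is not named here; a higher number here means a weaker inhibitor, a lower number a stronger inhibitor:

Compound 1, `O=C(COc1ccc2c(=O)ccoc2c1)Nc1cccc(NC(=O)c2ccc(F)cc2)c1`, gives 129 nM.
Compound 2, `O=C(COc1ccc2c(=O)ccoc2c1)Nc1cccc(NC(=O)c2ccc([N+](=O)[O-])cc2)c1`, gives 67 nM.
Compound 3, `Cc1nc(C(=O)Nc2cccc(NC(=O)COc3ccc4c(=O)ccoc4c3)c2)cs1`, gives 473 nM.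

Compound 3 stands at the highest number of the three, which in this assay means the weakest inhibitor: the step of a 3.7-fold higher number from compound 1 to compound 3 (0.56 log units; beyond the scatter) and the step of a 7.1-fold higher number from compound 2 to compound 3 (0.85 log units; beyond the scatter) both lie beyond the scatter, so its weaker standing is real and not a trick of repeated measurement.

Compound 4, `Nc1ccc(C(=O)Nc2cccc(NC(=O)COc3ccc4c(=O)ccoc4c3)c2)cc1`, has not yet been measured. It differs from compound 3 in one place: 4-aminophenyl in place of 2-methyl-1,3-thiazol-4-yl on a carbonyl carbon.

Among the compounds with values here, two measured steps bear on this change, read in reverse. Moving from a phenyl ring bearing fluoro to the thiazole gave a 3.7-fold higher number from compound 1 to compound 3 (0.56 log units; beyond the scatter), and moving from a phenyl ring bearing nitro to the thiazole gave a 7.1-fold higher number from compound 2 to compound 3 (0.85 log units; beyond the scatter). Putting a phenyl ring back in place of the thiazole would therefore be expected to lower the number again, by a modest amount of roughly that size. Compound 4 is accordingly estimated at 110 nM, with a range from 40 nM to 300 nM. This estimate means an expected step of a 4.3-fold lower number from compound 3 to compound 4 (0.63 log units; beyond the scatter) in this assay.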

Compound 4, half-maximal inhibitory concentration: 802 nM
For compound 4 the middle estimate is 7.3-fold (0.86 log units) below the measured one; the measured number lies above the stated range.
By their numbers in this assay, from the lowest: compounds 2 and 1 (each within the scatter of the next); then compounds 3 and 4 (each within the scatter of the next).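

In this assay, a phenyl ring on this carbonyl carbon does not by itself bring the number down: 4-aminophenyl in place of 2-methyl-1,3-thiazol-4-yl leaves the two compounds within the scatter of each other (a 1.7-fold higher number from compound 3 to compound 4 (0.23 log units; within the scatter)). What the ring carries makes the difference, with amino in place of nitro giving a large step (a 12-fold higher number from compound 2 to compound 4 (1.08 log units; beyond the scatter)) and amino in place of fluoro a modest one (a 6.2-fold higher number from compound 1 to compound 4 (0.79 log units; beyond the scatter)). Nothing measured here gives a reason for these differences.

On these data alone, it remains open how a phenyl ring with only hydrogen on that aromatic carbon would compare. A methoxy group, a carboxylic acid or a dimethylamino group there could stand nearer to compound 1 and compound 2 or nearer to compound 4.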